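The source may hold more compounds than are shown below. What is called first, only, known or untested is meant among the compounds shown, and "the series" means these compounds.

Four compounds built on one shared core are compared on a single read-out. In a functional assay on CHO cells for agonist activity at sphingosine 1-phosphate receptor 2 (Homo sapiens), read by fluorescence and calcium flux, with a stated time of 3 min (on this read-out higher numbers stand for weaker inhibition and lower numbers for stronger inhibition), compound 3, `CCOc1cc(NC(=O)NCc2cc(C)c(-c3cn(C)nc3C(F)(F)F)nn2)cc(C)n1`, gives 4400 nM. Compound 2, `CCOc1cc(NC(=O)NCc2cc(C)c(-c3cn(C)nc3C(F)(F)F)nn2)cc(C#N)n1`, gives 5500 nM in this assay. Compound 1, `Cc1cc(C#N)nc(NNC(=O)Nc2cc(Cl)nc(Cl)c2)c1`, gives > 23000 nM in this assay, which is a limit of the assay and not a number; this is the limit of > 23000 nM in this assay, at which 1 of the 3 values shown sits.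

Among the two numbers, compound 3 has the lowest, but the step of a 1.3-fold lower number from compound 2 to compound 3 (0.10 log units; within the scatter) lies within the scatter, so compound 2 and compound 3 stand level rather than one ahead of the other. Within the data shown here, that step, methyl in place of cyano on an aromatic carbon, is the only measured change that touches a cyano group.

Compound 4, `CCOc1nc(C)cc(NC(=O)NCc2cc(C)c(-c3cn(C)nc3C(F)(F)F)nn2)c1C#N`, differs from compound 3 by cyano in place of hydrogen on an aromatic carbon. Among the measured compounds shown here, no measured step places a cyano group at this position, and the single step that removes one, a 1.3-fold lower number from compound 2 to compound 3 (0.10 log units; within the scatter), moved the number by less than the scatter. A step beyond the scatter is therefore not expected, in either direction. The expected step that this estimate means, no change at the digits printed from compound 3 to compound 4 (within the scatter), is judged to sit within the scatter. Compound 4 is expected to give about 4400 nM in this assay, with a likely range from 1500 nM to 13000 nM.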

Compound 4, half-maximal inhibitory concentration: < 2300 nM
Compound 4: no number, only a limit; the forecaster's own chance of this, stated with the estimate: 5%; middle value at least 1.9-fold (0.28 log units) away from the limit.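

In this assay compound 4 gives < 2300 nM, which is a limit of the assay and not a number. Its true number therefore lies somewhere under that limit, and the step that adding the nitrile makes, an at least 1.9-fold lower number from compound 3 to compound 4 (0.28 log units; that floor lies within the scatter), is only a floor: the real gap could be that small or much larger, but on this read-out, where lower numbers stand for stronger inhibition, the nitrile on this carbon, ortho to an ethoxy group and para to a methyl group, does not leave the number higher. Among these compounds, the only earlier step touching a nitrile, a 1.3-fold lower number from compound 2 to compound 3 (0.10 log units; within the scatter), concerned another aromatic carbon of the same ring and showed no movement beyond the scatter, so this is the first sign that adding a nitrile here can go with a lower number.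

From the compounds shown here alone, how far under its limit compound 4 really sits stays open, and with it the true size of the step. Also open, going by these compounds, is whether an amine, a carboxylic acid or a longer chain on this same carbon would shift the number in the same direction as the nitrile.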